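The source may report more compounds than this note shows. Statements on the series, on what has been measured and on what is new or still open speak of the compounds shown alone.

Two compounds define the ground so far. Compound 1 `O=C(O)c1ccccc1-c1ccc(CCc2ncc(Cc3cccc(Cl)c3)[nH]2)cc1` gives 825 nM in an in vitro functional assay on cells for agonist activity at Bombesin receptor subtype-3 (Homo sapiens), read by luminescence and calcium flux (on this read-out lower numbers stand for an effect already at smaller amounts and higher numbers for an effect only at larger amounts of compound), the lowest of the two numbers in hand. Among the compounds with values here, compound 2 `CCCCc1cnc(C(CC)Cc2ccc(-c3ccccc3C(=O)O)cc2)[nH]1` gives 2720 nM in this assay, a higher number that lies beyond the scatter of compound 1, though the two differ in more than one place and no single step between them is computed.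

Compound 3 `N#Cc1ccccc1Cc1cnc(CCc2ccc(-c3ccccc3C(=O)O)cc2)[nH]1` has not yet been measured. It differs from compound 1 at one place: 2-cyanophenyl in place of 3-chlorophenyl on a saturated chain carbon bound to an aromatic carbon. Within the data shown here, no step between measured compounds speaks directly to this change, so the expectation rests on compound 1 alone, whose 825 nM in this assay is the anchor. The step of a 1.5-fold higher number from compound 1 to compound 3 (0.16 log units; within the scatter) is expected to be small, near the scatter or a little toward higher numbers. Compound 3 is estimated at 1200 nM, within a range from 400 nM to 4000 nM.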

Compound 3, half-maximal effective concentration: 5480 nM
Beside the measured number, compound 3's estimate is 4.6-fold (0.66 log units) below it, and the stated range ends below it.
By their numbers in this assay, from the lowest: compound 1; then compounds 2 and 3 (each within the scatter of the next).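

In this assay, the position on a saturated chain carbon bound to an aromatic carbon proves sensitive to what it carries: 2-cyanophenyl in place of 3-chlorophenyl gives a 6.6-fold higher number from compound 1 to compound 3 (0.82 log units; beyond the scatter). Within the data shown here, this is the first single-place step, and it shows that the aromatic group at this position cannot be exchanged freely, even though both groups keep one six-membered aromatic ring of carbon only. Nothing measured here explains why the number rises with this exchange.

The step replaces the chlorine with a nitrile and changes the ring position of the substituent at the same time, so the contribution of each remains unresolved. From the compounds shown here alone, how an unsubstituted phenyl, a methoxy group or an amine would behave on this ring also remains open.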